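Swapping one substituted phenyl group for another

This account rests on a few compounds, and the source may have more. Where it says the series, first, only, none or still open, it means among the compounds named here.

In a functional assay on A549 cells (Homo sapiens) for antiproliferative activity, read by MTT assay, with a stated time of 72 h (a lower number here means a stronger inhibitor, a higher number a weaker inhibitor), three compounds sharing one core have been measured. Compound 1 `CCNC(=O)c1cc(Oc2ccc(NC(=O)c3nn(-c4ccccc4OC(F)(F)F)c(=O)cc3C)cc2)ccn1` gives 5280 nM and compound 2 `CCNC(=O)c1cc(Oc2ccc(NC(=O)c3nn(-c4ccccc4C)c(=O)cc3C)cc2)ccn1` gives 34800 nM on this scale. Compound 3 `CCNC(=O)c1cc(Oc2ccc(NC(=O)c3nn(-c4ccc(C)cc4)c(=O)cc3C)cc2)ccn1` gives 11600 nM and so holds the second highest number of the three, between the other two.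

Compound 4 `CCNC(=O)c1cc(Oc2ccc(NC(=O)c3nn(-c4cccc(C(F)(F)F)c4)c(=O)cc3C)cc2)ccn1` differs from compound 3 in one place, with 3-(trifluoromethyl)phenyl in place of 4-methylphenyl on an aromatic nitrogen. Among the measured compounds shown here, no measured pair makes this exact swap, so the nearest steps must serve as a guide. All three are modest yet beyond the scatter. Changing the group on the ring gave a 6.6-fold higher number from compound 1 to compound 2 (0.82 log units; beyond the scatter) when methyl took the place of trifluoromethoxy. Exchanging 2-(trifluoromethoxy)phenyl for 4-methylphenyl gave a 2.2-fold higher number from compound 1 to compound 3 (0.34 log units; beyond the scatter). Exchanging 2-methylphenyl for 4-methylphenyl gave a 3.0-fold lower number from compound 2 to compound 3 (0.48 log units; beyond the scatter).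

For the measured compounds named here, compound 1 is the only measured compound with fluorine, and its group differs from the new one, so this evidence is thin. A modest move toward a lower number is expected in this assay. The estimated change is a 1.7-fold lower number from compound 3 to compound 4 (0.22 log units; within the scatter). For compound 4 the expected value is 7000 nM, within an estimated range of 2500 nM to 20000 nM.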

Compound 4, half-maximal inhibitory concentration: 10000 nM
Compound 4: middle estimate off by 1.4-fold (0.15 log units), on the low side, within the range that was stated.
By their numbers in this assay, from the lowest: compounds 1, 4 and 3 (each within the scatter of the next, the first and the last beyond it); then compound 2.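

In this assay, placing 3-(trifluoromethyl)phenyl on the aromatic nitrogen instead of 4-methylphenyl gives a 1.2-fold lower number from compound 3 to compound 4 (0.06 log units; within the scatter), so this swap brings fluorine onto the phenyl ring without a shift that can be told from the scatter. Set against the other groups, the same substituent gives a 1.9-fold higher number from compound 1 to compound 4 (0.28 log units; within the scatter), also within the scatter, and a 3.5-fold lower number from compound 2 to compound 4 (0.54 log units; beyond the scatter), which is beyond it, so compound 2, with 2-methylphenyl, now stands apart from all three others as the weakest of the set. Nothing measured here speaks to why these phenyl groups compare as they do.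

Compound 3 and compound 4 differ both in the group on the phenyl ring and in where it sits, so these compounds cannot show how much of the comparison belongs to each of those two features. It also remains open how this assay would read with an amine or a carboxylic acid on that phenyl ring, since every group shown there is a methyl or a fluorine-bearing group.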